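Adding a Methoxy Group to Compound 1

The compounds below may be only part of what the source reports. "The series", "measured", "known", "first", "only" and "open" are said of these compounds alone.

Within the data shown here, compound 1 `COc1ccc(-c2cc(/C=C/C(=O)c3ccc(N)cc3)[nH]n2)cc1` and compound 2 `COc1ccc(C(=O)/C=C/c2cc(-c3cc(OC)c(OC)c(OC)c3)n[nH]2)cc1` are the two measured members of this set. In a functional assay on KM12 cells (Homo sapiens) for cytotoxicity, read by sulforhodamine B assay, with a stated time of 48 h, tested at 0.01 uM (a lower number here means a stronger effect, a higher number a weaker effect of the compound at the concentration tested), compound 1 gives 96%, and compound 2 gives 99%; the two numbers lie within the usual scatter of each other, so neither stands apart. Compound 3 `COc1ccc(-c2cc(/C=C/C(=O)c3ccc(N)cc3)[nH]n2)cc1OC` differs from compound 1 by a single change: methoxy in place of hydrogen on an aromatic carbon. Among the measured compounds shown here, no measured pair shows this change, so its effect must be estimated. Because compound 1 gives 96% and compound 2 gives 99% in this assay, compound 3 is expected to move by no change at the digits printed from compound 1 to compound 3 (within the scatter), a step within the scatter. Compound 3 is estimated at 96%, ranging from 86% to 104%.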

Compound 3, a percentage reported as activity, at one concentration (the size of the read-out at that concentration, not a potency): 102%
Estimate against measurement, compound 3: 6 percentage points below, within the range that was stated.
By their numbers in this assay, from the lowest: compounds 1, 2 and 3 (each within the scatter of the next).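

In this assay, methoxy in place of hydrogen on this aromatic carbon, ortho to a methoxy group and meta to a large group, gives a number 6 percentage points higher from compound 1 to compound 3 (within the scatter). Among these compounds, this is the first single-change step in the set, and it shows no effect that can be told from the scatter at the one concentration tested. Nothing available here bears on the reason for this result.

On these data alone, whether another group on this carbon, such as an amine, a hydroxyl or a fluorine atom, would stand apart from compound 1 remains open. So does whether methoxy here would matter at a higher concentration.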